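One Ring Swap, Two Cores, One Leukemia Cell Assay

The compounds below may be only part of what the source reports. "The series", "measured", "known", "first", "only" and "open" are said of these compounds alone.

Four compounds are considered, all built on the same left-hand part and differing in a linker and in the group at the far end. Compound 1 `COc1cc(CNC(=O)CCCC/C=C/C(C)C)ccc1OC(=O)CCC(=O)Oc1ccc(-c2cc(=S)ss2)cc1` and compound 3 `COc1cc(CNC(=O)CCCC/C=C/C(C)C)ccc1OC(=O)CCC(=O)Oc1ccc(C(N)=S)cc1` carry the same linker and differ only at that far end; compound 2 `COc1cc(CNC(=O)CCCC/C=C/C(C)C)ccc1OCCCCCOc1ccc(C(N)=S)cc1` and compound 4 `COc1cc(CNC(=O)CCCC/C=C/C(C)C)ccc1OCCCCCOc1ccc(-c2cc(=S)ss2)cc1` carry another linker. The difference between the two cores is not broken down here.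

In a functional assay on K562 cells (Homo sapiens) for antiproliferative activity, read by MTT assay, with a stated time of 48 h (a lower number here means a stronger inhibitor, a higher number a weaker inhibitor), compound 1 gives 4450 nM. For compound 3 the value > 50000 nM is a limit of the assay rather than a number. The change from compound 3 to compound 1 is a group of 6 heavy atoms (3 carbon, 3 sulfur; one five-membered aromatic ring with 2 hetero atoms) in place of a group of 3 heavy atoms (1 carbon, 1 nitrogen, 1 sulfur; no ring), on an aromatic carbon, and it gave an at least 11-fold lower number from compound 3 to compound 1 (1.05 log units; beyond the scatter). That size rests on (the limit of > 50000 nM in this assay, at which 2 of the 3 values shown sit), so the true step may be larger than the figure shows.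

For compound 2 the value > 50000 nM is likewise a limit of this assay, not a number. Compound 4 is made from compound 2 by the same change, (a group of 6 heavy atoms (3 carbon, 3 sulfur; one five-membered aromatic ring with 2 hetero atoms) in place of a group of 3 heavy atoms (1 carbon, 1 nitrogen, 1 sulfur; no ring), on an aromatic carbon), at the same place. For compound 4 the expected step is an at least 6.2-fold lower number from compound 2 to compound 4 (0.79 log units; beyond the scatter), resting on the measured step of an at least 11-fold lower number from compound 3 to compound 1 (1.05 log units; beyond the scatter). The starting point for compound 2 is only a limit, which leaves the expected range wide. Compound 4 is expected to give about 8000 nM, somewhere between 2500 nM and 40000 nM.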

Compound 4, half-maximal inhibitory concentration: > 50000 nM
Compound 4: no number, only a limit; the forecaster's own chance of this, stated with the estimate: 20%; middle value at least 6.2-fold (0.79 log units) away from the limit.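

Compound 4 gives > 50000 nM in this assay, and this is a limit of the assay, not a number. Compound 2 sits at the same limit, so no step between compound 2 and compound 4 can be read: the limit of > 50000 nM in this assay, at which 3 of the 4 values shown sit.

From the compounds shown here alone, what stays open is whether the change at the far end, which gave a lower number for compound 1 than for compound 3, has any effect with the linker of compound 2 and compound 4.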